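Shortening an Ester Chain in a Kinase Inhibitor Series

The source may report more compounds than this note shows. Statements on the series, on what has been measured and on what is new or still open speak of the compounds shown alone.

Three compounds built on one shared core differ only in the length of an ester chain. Compound 1 `CCCCCCOC(=O)c1cccc(-c2cc(C(=O)Nc3ccncc3)ccc2CN)c1` carries the longest chain; in an assay on isolated protein for inhibition of Rho-associated protein kinase 2 (Homo sapiens), read by radiometric assay (on this read-out lower numbers stand for stronger inhibition and higher numbers for weaker inhibition), compound 1 gives 22 nM. Compound 2 `CCCCCOC(=O)c1cccc(-c2cc(C(=O)Nc3ccncc3)ccc2CN)c1` gives 4.9 nM in this assay. Compound 3 `CCOC(=O)c1cccc(-c2cc(C(=O)Nc3ccncc3)ccc2CN)c1` carries the shortest chain. For compound 3 the figure of < 1 nM in this assay is a limit of the assay rather than a number (the limit of < 1 nM in this assay, at which 1 of the 3 values shown sits). Compound 3 differs from compound 2 by hydrogen in place of propyl on a saturated chain carbon, two bonds along the chain from an oxygen next to a carbonyl group, with the step of an at least 4.9-fold lower number from compound 2 to compound 3 (0.69 log units; beyond the scatter). Compound 1 differs from compound 2 by methyl in place of hydrogen on a saturated chain carbon, five bonds along the chain from an oxygen next to a carbonyl group, giving a 4.5-fold higher number from compound 2 to compound 1 (0.65 log units; beyond the scatter). The larger shortening gives an at least 22-fold lower number from compound 1 to compound 3 (1.34 log units; beyond the scatter).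

Compound 4 `CCCOC(=O)c1cccc(-c2cc(C(=O)Nc3ccncc3)ccc2CN)c1` is not yet measured. It differs from compound 3 by methyl in place of hydrogen on a saturated chain carbon, two bonds along the chain from an oxygen next to a carbonyl group. This is the same kind of change as from compound 2 to compound 1, though not the same: there the added methyl sits five bonds along the chain from an oxygen next to a carbonyl group, here two bonds along. Compound 4 is expected to give 1.6 nM in this assay. The expected step of an at least 1.6-fold higher number from compound 3 to compound 4 (0.20 log units; that floor lies within the scatter) is judged similar to or smaller than a 4.5-fold higher number from compound 2 to compound 1 (0.65 log units; beyond the scatter), since compound 2 with its longer chain gives 4.9 nM and compound 4 sits between compound 3 and compound 2 in chain length.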

Compound 4, half-maximal inhibitory concentration: 1.4 nM
The estimate for compound 4 lay 1.1-fold (0.06 log units) above the measured number; low and high end bracket the measured number.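

In this assay, going by these compounds, adding the methyl to the shorter chain gives an at least 1.4-fold higher number from compound 3 to compound 4 (0.14 log units; that floor lies within the scatter), so the true size of this step stays unknown. The figure for compound 3 is a limit of the assay and not a number, so it cannot be said whether the addition weighs as much on the shorter chain as on the longer one: the same change on two cores in this assay, a 4.5-fold higher number (0.65 log units; beyond the scatter) from compound 2 to compound 1 and an at least 1.4-fold higher number (0.14 log units; that floor lies within the scatter) from compound 3 to compound 4; the limit leaves it open whether they differ Shortening the chain does carry over in direction, with a 3.5-fold lower number from compound 2 to compound 4 (0.54 log units; beyond the scatter) and a 16-fold lower number from compound 1 to compound 4 (1.20 log units; beyond the scatter), but how closely the sizes of such shortenings match stays unsettled as well: the same change on two cores in this assay, an at least 4.9-fold lower number (0.69 log units; beyond the scatter) from compound 2 to compound 3 and a 16-fold lower number (1.20 log units; beyond the scatter) from compound 1 to compound 4; the limit leaves it open whether they differ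

The compounds shown leave open whether a methyl ester, with a still shorter chain, or a branched isopropyl ester would keep the number as low as in compound 4. They also leave open what a carboxylic acid in place of the ester would give, and only an exact figure for compound 3 could settle the size of its step to compound 4.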